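Dropping a methoxy group: from compound 1 to compound 3

A few compounds are considered here, and "the series" means these few. Any claim that something is new, unique, unknown or untested is made for them only; others in the source may bear on it.

Compound 1, `COc1ccccc1/C=C/C(=O)c1ccc(OCC(=O)N[C@H]2CCOC2=O)cc1`, was run in a functional assay on MGC-803 cells (Homo sapiens) for antiproliferative activity, read by MTT assay, with a stated time of 72 h (on this read-out higher numbers stand for weaker inhibition and lower numbers for stronger inhibition), where compound 1 gives 39400 nM. Among the results shown here this is the only true number; the one other value reported is a limit of the assay. That other entry belongs to compound 2, `O=C(CNc1ccccc1)N[C@H]1CCOC1=O`, for which this assay reports only > 64000 nM, a limit of the assay and not a number. Among the measured compounds shown here, this is the limit of > 64000 nM in this assay, at which 1 of the 2 values shown sits, and with compound 2 sitting there, no measured step of the kind that would guide the next move is available, since compound 1 and compound 2 differ in more than one place.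

The compound still to be tested is compound 3, `O=C(COc1ccc(C(=O)/C=C/c2ccccc2)cc1)N[C@H]1CCOC1=O`. It differs from compound 1 by hydrogen in place of methoxy on an aromatic carbon. For the measured compounds named here, with no measured step to compare, the change is expected to stay within the usual scatter of this assay, with the step from compound 1 to compound 3 estimated as a 1.1-fold higher number from compound 1 to compound 3 (0.03 log units; within the scatter). Compound 3 is accordingly expected to give about 42000 nM, somewhere between 14000 nM and 125000 nM.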

Compound 3, half-maximal inhibitory concentration: > 64000 nM
Compound 3 ended at the assay's limit; the forecaster's own chance of this, stated with the estimate: 30%; middle value at least 1.5-fold (0.18 log units) from the limit.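

Going from 2-methoxyphenyl to phenyl is the first change in this assay that can be read at a single place on the shared core, and it gives an at least 1.6-fold higher number from compound 1 to compound 3 (0.21 log units; that floor lies within the scatter). For compound 3 the assay reports only a limit, > 64000 nM, and not a number, so the step has a known floor but no known size, and that floor alone does not separate compound 3 from compound 1. What this adds is that taking away the methoxy group leaves no measurable value for this compound, and compound 1 remains the only compound shown with a true number, while compound 3 joins compound 2 at the end of the range the assay reports: the limit of > 64000 nM in this assay, at which 2 of the 3 values shown sit.

Going by these compounds, whether the loss of the methoxy group truly matters beyond the usual scatter therefore stays open, since a limit cannot settle it. Also open, on these data alone, is how other groups on this aromatic carbon would read in this assay, such as a hydroxyl, a chlorine atom, an amine or a longer ethoxy chain in place of the methoxy.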